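Substituents on the benzyl ring of the piperidine amides

The source may report more compounds than this note shows. Statements on the series, on what has been measured and on what is new or still open speak of the compounds shown alone.

Measured so far:
compound 1 `CC(C)(C)c1cc(/C=C/C(=O)NCCC2CCN(Cc3ccccc3)CC2)cc(C(C)(C)C)c1O`: 8500 nM
compound 2 `CC(C)(C)c1cc(/C=C/C(=O)NCCC2CCN(Cc3ccc(F)cc3)CC2)cc(C(C)(C)C)c1O`: 11100 nM
compound 3 `CC(C)(C)c1cc(/C=C/C(=O)NCCC2CCN(Cc3ccccc3Cl)CC2)cc(C(C)(C)C)c1O`: 9800 nM

In an assay on isolated protein for inhibition of Amine oxidase [flavin-containing] B (Homo sapiens), read by fluorescence, with stated times of 15 min and 20 min (on this read-out lower numbers stand for stronger inhibition and higher numbers for weaker inhibition), compound 1 carries the smallest of the three numbers, yet the steps to its neighbours, a 1.2-fold higher number from compound 1 to compound 3 (0.06 log units; within the scatter) and a 1.3-fold higher number from compound 1 to compound 2 (0.12 log units; within the scatter), both fall within the scatter, so the three compounds are not separated. Compound 4 `CC(C)(C)c1cc(/C=C/C(=O)NCCC2CCN(Cc3ccc(C#N)cc3)CC2)cc(C(C)(C)C)c1O` carries a further change on the same ring: cyano in place of hydrogen on an aromatic carbon. The two steps that bear on it are those aromatic substitutions, fluoro and chloro, and neither moved the number beyond the scatter. The expected step for compound 4 is therefore a 1.1-fold higher number from compound 1 to compound 4 (0.05 log units; within the scatter), no shift beyond the scatter. Compound 4 is estimated at 9500 nM, within 5000 nM to 19000 nM.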

Compound 4, half-maximal inhibitory concentration: 13900 nM
Beside the measured number, compound 4's estimate is 1.5-fold (0.17 log units) below it, within the range that was stated.
By their numbers in this assay, from the lowest: compounds 1, 3, 2 and 4 (each within the scatter of the next).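

In this assay the nitrile stays within the scatter at this position on the benzyl ring, against hydrogen (a 1.6-fold higher number from compound 1 to compound 4 (0.21 log units; within the scatter)), against 2-chloro (a 1.4-fold higher number from compound 3 to compound 4 (0.15 log units; within the scatter)) and against 4-fluoro (a 1.3-fold higher number from compound 2 to compound 4 (0.10 log units; within the scatter)). A group of two heavy atoms with a triple bond and one hydrogen-bond acceptor therefore separates compound 4 from none of the other three compounds. No measurement is available that bears on the reason for these small steps.

From the compounds shown here alone, whether an amine, a carboxylic acid or a longer chain on this ring would give a step beyond the scatter remains open.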